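Replacing the 4-bromophenyl group: working notes toward compound 4

The source may hold more compounds than are shown below. What is called first, only, known or untested is meant among the compounds shown, and "the series" means these compounds.

Measured in a functional assay on L1210 cells (Mus musculus) for antiproliferative activity; on this read-out higher numbers stand for weaker inhibition and lower numbers for stronger inhibition:
- compound 1, `COc1cc(C(=O)c2sc(-c3ccc(Br)cc3)cc2N)cc(OC)c1OC`, gives 100 nM
- compound 2, `COc1cc(C(=O)c2sc(-c3ccc(I)cc3)cc2N)cc(OC)c1OC`, gives 400 nM
- compound 3, `COc1cc(C(=O)c2sc(-c3ccncc3)cc2N)cc(OC)c1OC`, gives 1810 nM

Compound 1 stands lowest of the three; the nearest is compound 2 with a 4.0-fold higher number from compound 1 to compound 2 (0.60 log units; beyond the scatter), the furthest compound 3 with an 18-fold higher number from compound 1 to compound 3 (1.26 log units; beyond the scatter).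

Compound 4, `COc1cc(C(=O)c2sc(-c3ccsc3)cc2N)cc(OC)c1OC`, differs from compound 1 as follows: thiophen-3-yl in place of 4-bromophenyl on an aromatic carbon.

Within the data shown here, two measured steps bear on this. Exchanging one ring for another at the same position gave an 18-fold higher number from compound 1 to compound 3 (1.26 log units; beyond the scatter), a large loss; a change within the 4-bromophenyl group gave a 4.0-fold higher number from compound 1 to compound 2 (0.60 log units; beyond the scatter). A step in this assay toward a higher number is therefore expected, probably between those two in size.

For compound 4 the expected value is 400 nM, with a range of 130 nM to 1300 nM, amounting to an expected 4.0-fold higher number from compound 1 to compound 4 (0.60 log units; beyond the scatter).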

Compound 4, half-maximal inhibitory concentration: 12 nM
Compound 4: the middle estimate sits 33-fold (1.52 log units) above what was measured; the measured number lies below the stated range.
By their numbers in this assay, from the lowest: compound 4; then compound 1; then compound 2; then compound 3.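

In this assay, exchanging the ring at this position need not cost activity: thiophen-3-yl in place of 4-bromophenyl gives (an 8.3-fold lower number from compound 1 to compound 4 (0.92 log units; beyond the scatter)). The gaps to the other two rings are wider (a 33-fold lower number from compound 2 to compound 4 (1.52 log units; beyond the scatter); a 150-fold lower number from compound 3 to compound 4 (2.18 log units; beyond the scatter)), so among these four compounds a halogen-bearing phenyl ring is not needed for the lowest number. Nothing shown accounts for this gain.

On these data alone, whether thiophen-2-yl or furan-3-yl would match thiophen-3-yl remains open. So does the effect of a methyl group or an amine on the thiophen-3-yl ring.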